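Compound 4: double bond configuration against compound 3

This account rests on a few compounds, and the source may have more. Where it says the series, first, only, none or still open, it means among the compounds named here.

Measured in a functional assay on HCT-116 cells (Homo sapiens) for inhibition; on this read-out lower numbers stand for stronger inhibition and higher numbers for weaker inhibition:
- Compound 1 `Cc1ccc(/C=C\c2ccc3ccccc3c2)cc1` gives > 5000 nM as a limit
- Compound 2 `FC(F)(F)c1ccc(/C=C\c2ccc3ccccc3c2)cc1` gives > 5000 nM as a limit
- Compound 3 `CN(C)c1ccc(/C=C/c2ccc3ccccc3c2)cc1` gives 3660 nM as a number

Within the data shown here, compound 3 holds the only number here, while compound 1 and compound 2 share the limit of > 5000 nM in this assay, at which 2 of the 3 values shown sit, in the notes. Compound 4 `CN(C)c1ccc(/C=C\c2ccc3ccccc3c2)cc1` is set against compound 3 as follows (the two compounds have the same atoms and bonds and differ only in configuration as drawn: 1 of 1 stereo elements differ; a double bond is drawn E in compound 3 and Z in compound 4). Among the measured compounds shown here, the one measured step is a step that the two limits leave unreadable from compound 1 to compound 2 and concerns a substituent, so it gives no size for this change. For the measured compounds named here, no measured pair isolates the configuration of the double bond. The value of compound 3 at 3660 nM is therefore the only anchor, and no direction is expected. The expected change is a 1.0-fold lower number from compound 3 to compound 4 (0.02 log units; within the scatter) and stays within the scatter. For compound 4 the estimate is 3500 nM with an expected range of 1000 nM to 10000 nM in this assay as the read-out.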

Compound 4, half-maximal inhibitory concentration: 3660 nM
For compound 4 the middle estimate is 1.0-fold (0.02 log units) below the measured one, and the stated range covers the measured number.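

In this assay the double bond configuration shows no change at the digits printed from compound 3 to compound 4 (within the scatter). With the double bond drawn Z in all three compounds, dimethylamino gives an at least 1.3-fold lower number from compound 2 to compound 4 (0.13 log units; that floor lies within the scatter) and an at least 1.3-fold lower number from compound 1 to compound 4 (0.13 log units; that floor lies within the scatter). Both floors rest on a limit and not on a number: the limit of > 5000 nM in this assay, at which 2 of the 4 values shown sit.

Going by these compounds, it remains open whether the E and Z forms stay alike with a substituent other than dimethylamino. Also open, on these data alone, is whether a primary amine or a carboxylic acid in its place would move the number beyond the scatter.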